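Carbamate shortening at the aryl nitrogen: ethyl for tert-butyl

The compounds below may be only part of what the source reports. "The series", "measured", "known", "first", "only" and "open" are said of these compounds alone.

The series shares one core, shown for compound 1 as `Nc1cccc(-c2csc(NC(=O)CCCCCC(=O)Nc3ccccc3N)n2)c1`; in an assay on isolated protein for inhibition of polyamine deacetylase HDAC10 (Homo sapiens), read by fluorescence, with a stated time of 17 h (a lower number here means a stronger inhibitor, a higher number a weaker inhibitor), compound 1 gives 2910 nM. Compound 2 `CC(=O)Nc1cccc(-c2csc(NC(=O)CCCCCC(=O)Nc3ccccc3N)n2)c1` carries an acetyl on the ring nitrogen and gives 3000 nM in this assay, a change of a 1.0-fold higher number from compound 1 to compound 2 (0.01 log units; within the scatter). Compound 3 `CC(C)(C)OC(=O)Nc1cccc(-c2csc(NC(=O)CCCCCC(=O)Nc3ccccc3N)n2)c1` carries a tert-butoxycarbonyl there and gives 5300 nM, so compound 3 has the highest number of the three, but the steps of a 1.8-fold higher number from compound 1 to compound 3 (0.26 log units; within the scatter) and a 1.8-fold higher number from compound 2 to compound 3 (0.25 log units; within the scatter) both lie within the scatter.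

Compound 4 `CCOC(=O)Nc1cccc(-c2csc(NC(=O)CCCCCC(=O)Nc3ccccc3N)n2)c1` differs from compound 3 by ethyl in place of tert-butyl on an oxygen next to a carbonyl group. Going by the values given here, the nearest measured steps are a 1.8-fold higher number from compound 2 to compound 3 (0.25 log units; within the scatter), the only other change at the carbonyl carbon, and a 1.8-fold higher number from compound 1 to compound 3 (0.26 log units; within the scatter); neither moved the number beyond the scatter, and nothing separates one substituent on the ring nitrogen from another. Compound 4 is therefore expected to stay close to compound 3, with a step of a 1.2-fold lower number from compound 3 to compound 4 (0.07 log units; within the scatter) in this assay. The estimate for compound 4 is 4500 nM, in the range 2200 nM to 9000 nM.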

Compound 4, half-maximal inhibitory concentration: > 30000 nM
Compound 4 was reported as a limit (the forecaster's own chance of this, stated with the estimate: 5%); middle value at least 6.6-fold (0.82 log units) away from the limit.
By their numbers in this assay, from the lowest: compounds 1, 2 and 3 (each within the scatter of the next). At a limit, above all of these: compound 4.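

In this assay compound 4 is reported only as a limit: the limit of > 30000 nM in this assay, at which 1 of the 4 values shown sits. The substituent on the aromatic ring nitrogen, which made no difference beyond the scatter across hydrogen, acetyl and tert-butoxycarbonyl, now matters: the swap on the oxygen next to a carbonyl group gives an at least 5.6-fold higher number from compound 3 to compound 4 (0.75 log units; beyond the scatter), and the other two comparisons give an at least 10-fold higher number from compound 2 to compound 4 (1.00 log units; beyond the scatter) and an at least 10-fold higher number from compound 1 to compound 4 (1.01 log units; beyond the scatter). A carbamate at this nitrogen is therefore not enough to predict the outcome, since ethoxycarbonyl and tert-butoxycarbonyl part beyond the scatter.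

From the compounds shown here alone, how far compound 4 lies past its limit stays open, and with it the true size of all three steps. Also open, going by these compounds, is whether ethyl alone behaves this way: methyl, isopropyl or a longer chain such as n-butyl on the same oxygen would settle that.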